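The compounds below may be only part of what the source reports. "The series", "measured", "known", "first", "only" and "open" are said of these compounds alone.

Compound 1 `c1ccc(-c2ccoc2)c(OCC2=NCCN2)c1`: 0.501 nM
Compound 2 `c1ccc(-c2ncc[nH]2)c(OCC2=NCCN2)c1`: 100 nM

Among the measured compounds shown here, in a functional assay for activation of Alpha-1A adrenergic receptor (Homo sapiens), read by calcium flux (a higher number here means that more compound is needed for the effect, a lower number that less compound is needed), compound 2 gives 100 nM, the higher of the two numbers measured so far; compound 1 gives 0.501 nM. Compound 3 `c1ccc(-c2nccs2)c(OCC2=NCCN2)c1` differs from compound 2 by 1,3-thiazol-2-yl in place of 1H-imidazol-2-yl on an aromatic carbon. For the measured compounds named here, only one measured step bears on this change: a 200-fold higher number from compound 1 to compound 2 (2.30 log units; beyond the scatter), where a ring carrying one hydrogen-bond donor replaced a ring with none. Compound 3 again carries no hydrogen-bond donor, so a lower number than compound 2 is expected, though a full return to the level of compound 1 is not assumed. Compound 3 is estimated at 5 nM, within a range of 0.5 nM to 50 nM, which means an expected step of a 20-fold lower number from compound 2 to compound 3 (1.30 log units; beyond the scatter).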

Compound 3, half-maximal effective concentration: 2.51 nM
Compound 3: the middle estimate sits 2.0-fold (0.30 log units) above what was measured; the range from low to high includes it.
By their numbers in this assay, from the lowest: compound 1; then compound 3; then compound 2.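

Putting 1,3-thiazol-2-yl in place of 1H-imidazol-2-yl on this aromatic carbon gives a 40-fold lower number from compound 2 to compound 3 (1.60 log units; beyond the scatter) and so recovers most of the earlier loss. The recovery is not complete, with a 5.0-fold higher number from compound 1 to compound 3 (0.70 log units; beyond the scatter) remaining between the two rings that have no hydrogen-bond donor. Among these three compounds, only the ring in compound 2 carries a hydrogen-bond donor, and compound 2 gives 100 nM, the highest number of the three.

Going by these compounds, how a plain phenyl ring, a methoxy group or an amine would behave at this position remains open. Nothing available explains the differences among these rings.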